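The source may report more compounds than this note shows. Statements on the series, on what has been measured and on what is new or still open speak of the compounds shown alone.

The measured compounds, each with its number in a functional assay (aorta) for antagonist activity, with Oryctolagus cuniculus as the target; a higher number here means a weaker inhibitor, a lower number a stronger inhibitor:

compound 1, `CCCCc1ccc(CNCc2ccccc2)c(=O)n1Cc1ccc(-c2ccccc2-c2nn[nH]n2)cc1`, gives 1 nM
compound 2, `CCCCc1ccc(CNC(C)=O)c(=O)n1Cc1ccc(-c2ccccc2-c2nn[nH]n2)cc1`, gives 3 nM
compound 3, `CCCCc1ccc(CNS(=O)(=O)c2ccccc2)c(=O)n1Cc1ccc(-c2ccccc2-c2nn[nH]n2)cc1`, gives 7 nM

Compound 2 holds the second highest of the three numbers. Its nearest neighbour is compound 3, reached by a 2.3-fold higher number from compound 2 to compound 3 (0.37 log units; beyond the scatter); its furthest is compound 1, from which compound 2 is reached by a 3.0-fold higher number from compound 1 to compound 2 (0.48 log units; beyond the scatter). Compound 1 to compound 3 is the widest step of the set, a 7.0-fold higher number from compound 1 to compound 3 (0.85 log units; beyond the scatter).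

Compound 4, `CCCCc1ccc(CN(C)S(C)(=O)=O)c(=O)n1Cc1ccc(-c2ccccc2-c2nn[nH]n2)cc1`, has not been measured. Relative to compound 2 the difference is methyl(methylsulfonyl)amino in place of acetamido on a saturated chain carbon bound to an aromatic carbon. Among the compounds with values here, the only measured step that touches this change is the one from compound 2 to compound 3, where a sulfonyl group on the same nitrogen replaced the acetyl and the number rose modestly; the step from compound 1 to compound 2 also shows that small groups on that nitrogen are tolerated without large loss. Compound 4 carries both a sulfonyl and a second methyl on the nitrogen, so a modest weakening in this assay is expected, about the size seen from compound 2 to compound 3. The expected step is a 2.7-fold higher number from compound 2 to compound 4 (0.43 log units; beyond the scatter). Compound 4 is therefore estimated at 8 nM, with a range from 3 nM to 25 nM.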

Compound 4, half-maximal inhibitory concentration: 0.2 nM
Compound 4: the middle estimate sits 40-fold (1.60 log units) above what was measured, and the stated range ends above it.
By their numbers in this assay, from the lowest: compound 4; then compound 1; then compound 2; then compound 3.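

In this assay, within the data shown here, the place on a saturated chain carbon bound to an aromatic carbon proves able to carry far more potency than the earlier compounds showed, with methyl(methylsulfonyl)amino in place of acetamido giving a 15-fold lower number from compound 2 to compound 4 (1.18 log units; beyond the scatter). The sulfonyl link does not by itself raise the number, as the earlier sulfonyl example alone might have suggested: compound 3 and compound 4 both carry a sulfonyl, yet the change gives a 35-fold lower number from compound 3 to compound 4 (1.54 log units; beyond the scatter), and the benzylamino group of compound 1, previously the best here, is also passed, with a 5.0-fold lower number from compound 1 to compound 4 (0.70 log units; beyond the scatter). The data offered give no explanation for this gain.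

Compound 4 differs from compound 3 both in the methyl on the nitrogen and in the methyl in place of phenyl on the sulfur, so the compounds shown cannot apportion the gain between these two features. Still open, going by these compounds, is where (methylsulfonyl)amino, which lacks the nitrogen methyl, and methyl(acetyl)amino, which keeps that methyl but has a carbonyl in place of the sulfonyl, would fall.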